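From benzyl to 4-bromophenyl on the shared core

The source may report more compounds than this note shows. Statements on the series, on what has been measured and on what is new or still open speak of the compounds shown alone.

Three compounds with the same core differ in the group on an aromatic nitrogen: compound 1 `CCCCn1ccnc1-c1cc(OC)c(OC)c(OC)c1`, compound 2 `COc1cc(-c2nccn2Cc2ccccc2)cc(OC)c1OC` and compound 3 `COc1cc(-c2nccn2-c2ccc3cc[nH]c3c2)cc(OC)c1OC`. They were examined in an ADME assay on HUVEC cells (Homo sapiens) for cytotoxicity, read by MTT assay, with a stated time of 72 h (a higher number here means a weaker inhibitor, a lower number a stronger inhibitor), but only one of them has a number. Compound 1 has no usable result ("not determined" (no result reported)) and compound 2 is in the same position ("not determined" (no result reported)). Going by the values given here, compound 3 gives the only measured value (40000 nM). Compound 2 therefore has no place on the scale, since a compound without a number cannot be ranked above or below another.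

Compound 4 `COc1cc(-c2nccn2-c2ccc(Br)cc2)cc(OC)c1OC` is built from compound 2 by one change, with 4-bromophenyl in place of benzyl on an aromatic nitrogen. Among the compounds with values here, no measured step shows what such a swap does, so neither the size nor the direction of a change from compound 2 can be read from the data. The nearest guide is compound 3 (40000 nM), which also carries an aromatic group directly on that nitrogen. The expectation is therefore a result no different from compound 3 beyond the usual scatter, with wide uncertainty. For compound 4 the estimated value is 30000 nM in this assay with a range from 10000 nM to 100000 nM expected.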

Compound 4, half-maximal inhibitory concentration: > 100000 nM
Compound 4: only a limit was reported; the forecaster's own chance of this, stated with the estimate: 25%; at least 3.3-fold (0.52 log units) between middle value and limit.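

In this assay, going by these compounds alone, compound 2 has no number, so no step from it to compound 4 can be read. For compound 4 the reported > 100000 nM is a limit of the assay and not a number. The compounds shown leave open how far, and in which direction, replacing benzyl with 4-bromophenyl moves this read-out.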